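From Oxazole to Methoxyazetidine: Expected Distribution of Compound 4

This account rests on a few compounds, and the source may have more. Where it says the series, first, only, none or still open, it means among the compounds named here.

Compound 1 `CCn1c(-c2cnc(C)nc2)nc2c(N[C@H]3CCN(C(=O)C4CCC4)C3)ncnc21`, compound 2 `CCn1c(-c2cnc(C)nc2)nc2c(N[C@H]3CCN(C(=O)C4CCOC4)C3)ncnc21` and compound 3 `CCn1c(-c2ccc(C(F)(F)F)nc2)nc2c(O[C@H]3CCN(C(=O)c4cocn4)C3)ncnc21` have been measured in an ADME assay (Rattus norvegicus, strain Wistar Han) for pharmacokinetics; on this read-out lower numbers stand for narrower distribution and higher numbers for wider distribution into tissues. In this assay compound 1 gives 9.2 L/kg, compound 2 gives 2.3 L/kg and compound 3 gives 2.6 L/kg. Among the compounds with values here, the only measured step, a 4.0-fold lower number from compound 1 to compound 2 (0.60 log units; beyond the scatter), swaps one ring for another on the carbonyl carbon. Compound 3 stands second highest of the three: its number sits within the scatter of compound 2 and beyond the scatter under compound 1. Compound 4 `CCn1c(-c2ccc(C(F)(F)F)nc2)nc2c(O[C@H]3CCN(C(=O)N4CC(OC)C4)C3)ncnc21` differs from compound 3 by 3-methoxyazetidin-1-yl in place of 1,3-oxazol-4-yl on a carbonyl carbon. Within the data shown here, this change also sits on a carbonyl carbon, yet no measured step covers a five-membered aromatic ring giving way to a four-membered non-aromatic one, so the step from compound 1 to compound 2 is only loose guidance. Compound 4 is therefore expected to remain close to compound 3, with a 1.0-fold lower number from compound 3 to compound 4 (0.02 log units; within the scatter). The estimate for compound 4 is 2.5 L/kg, ranging from 1.2 L/kg to 5.2 L/kg.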

Compound 4, volume of distribution: 4.2 L/kg
Estimate against measurement, compound 4: 1.7-fold (0.23 log units) below; low and high end bracket the measured number.
By their numbers in this assay, from the lowest: compounds 2, 3 and 4 (each within the scatter of the next); then compound 1.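

At this carbonyl carbon, 3-methoxyazetidin-1-yl takes the place of 1,3-oxazol-4-yl with a 1.6-fold higher number from compound 3 to compound 4 (0.21 log units; within the scatter) in this assay. A five-membered aromatic ring and a four-membered non-aromatic ring therefore cannot be told apart on this read-out, unlike the cyclobutyl and oxolan-3-yl pair, which showed a 4.0-fold lower number from compound 1 to compound 2 (0.60 log units; beyond the scatter). Nothing on hand gives a reason for this result. Still open, on these data alone, is whether a dimethylamino group or a piperidine ring at this carbonyl carbon would also stay within the scatter of compound 3. Whether the same swap behaves alike on the core of compound 1 is also unknown.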